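Methoxy in Place of Iodo on the Benzamide Ring

The compounds below may be only part of what the source reports. "The series", "measured", "known", "first", "only" and "open" are said of these compounds alone.

Of the compounds shown here, three sharing one core have been measured. Compound 1 `COc1ccccc1NC(=S)N1CCc2c(sc(NC(=O)c3ccccc3Cl)c2C(N)=O)C1` carries a chloro group on its benzamide ring, and in a functional assay on HL-60 cells (Homo sapiens) for antiproliferative activity, with a stated time of 24 h (on this read-out lower numbers stand for stronger inhibition and higher numbers for weaker inhibition), compound 1 gives 40900 nM. Compound 2 `COc1ccccc1C(=O)Nc1sc2c(c1C(N)=O)CCN(C(=S)Nc1ccccc1Cl)C2` gives 20800 nM in this assay. For compound 3 `COc1ccccc1NC(=S)N1CCc2c(sc(NC(=O)c3ccccc3I)c2C(N)=O)C1` this assay reports only a limit, > 50000 nM, so its exact position is not known. Replacing chloro with iodo gave an at least 1.2-fold higher number from compound 1 to compound 3 (0.08 log units; that floor lies within the scatter), which is no more than the ordinary scatter of this assay.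

Compound 4 `COc1ccccc1NC(=S)N1CCc2c(sc(NC(=O)c3ccccc3OC)c2C(N)=O)C1` has not been measured; its difference from compound 3 is methoxy in place of iodo on an aromatic carbon. Going by the values given here, no measured step covers a halogen-to-methoxy exchange, and the one measured step on this ring, chloro to iodo, changed little. The expectation is therefore that compound 4 stays in the same weakly inhibiting region, with an estimated step of an at least 1.1-fold lower number from compound 3 to compound 4 (0.04 log units; that floor lies within the scatter). Compound 4 is estimated to give about 45000 nM in this assay, most likely between 15000 nM and 150000 nM, with a real chance that only a limit is reported again.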

Compound 4, half-maximal inhibitory concentration: > 50000 nM
Compound 4: a limit, no number; the forecaster's own chance of this, stated with the estimate: 50%; middle value at least 1.1-fold (0.04 log units) away from the limit.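

With methoxy on the benzamide ring, compound 4 gives only a limit, as compound 3 does, and the step between them cannot be read because neither has a number: the limit of > 50000 nM in this assay, at which 2 of the 4 values shown sit.

Set against chloro on the same ring, the exchange gives an at least 1.2-fold higher number from compound 1 to compound 4 (0.08 log units; that floor lies within the scatter) and so neither iodo nor methoxy has yet shown a gain over chloro at this position. A step beyond the scatter appears only on the other aromatic ring, where exchanging chloro for methoxy, with methoxy already on the benzamide ring, gives an at least 2.4-fold higher number from compound 2 to compound 4 (0.38 log units; beyond the scatter) and points to that ring as the more responsive place among the compounds shown.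

On these data alone, the order of compound 3 and compound 4 remains unknown. Also open, as far as these compounds go, is whether an amine or a carboxylic acid on the benzamide ring would bring the number down into a range where it can be read.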